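Methyl to Methoxy, Seen Once and Tried Again

The source may hold more compounds than are shown below. What is called first, only, known or untested is meant among the compounds shown, and "the series" means these compounds.

Three compounds have been measured in a functional assay on HepG2 cells (Homo sapiens) for cytotoxicity, read by MTT assay, with a stated time of 48 h; a higher number here means a weaker inhibitor, a lower number a stronger inhibitor:
compound 1 `Cc1ccccc1-c1nnc(SCCn2c([N+](=O)[O-])cnc2C)o1` gives 5100 nM
compound 2 `COc1ccccc1-c1nnc(SCCn2c([N+](=O)[O-])cnc2C)o1` gives 10000 nM
compound 3 `Cc1ccc(-c2nnc(SCCn3c([N+](=O)[O-])cnc3C)o2)c(O)c1` gives 16600 nM

Compound 2 differs from compound 1 by methoxy in place of methyl on an aromatic carbon, and the step of a 2.0-fold higher number from compound 1 to compound 2 (0.29 log units; within the scatter). Compound 3 rests on a different core, which differs from that of compound 1 by 2-hydroxy-4-methylphenyl in place of 2-methylphenyl on an aromatic carbon; in this assay the step of a 3.3-fold higher number from compound 1 to compound 3 (0.51 log units; beyond the scatter), whereas a 1.7-fold higher number from compound 2 to compound 3 (0.22 log units; within the scatter).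

Compound 4 `COc1ccc(-c2nnc(SCCn3c([N+](=O)[O-])cnc3C)o2)c(O)c1` has not been measured. It differs from compound 3 by methoxy in place of methyl on an aromatic carbon. This is the same kind of change as from compound 1 to compound 2, but its surroundings differ: in the earlier pair the entering methoxy is ortho to a large group, here it is meta to a hydroxy group and para to a large group. Because a 2.0-fold higher number from compound 1 to compound 2 (0.29 log units; within the scatter), compound 4 is expected to move by about a 1.5-fold higher number from compound 3 to compound 4 (0.18 log units; within the scatter). Compound 4 is therefore estimated at 25000 nM, with a likely range from 10000 nM to 60000 nM.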

Compound 4, half-maximal inhibitory concentration: 11000 nM
Estimate against measurement, compound 4: 2.3-fold (0.36 log units) above, and the stated range covers the measured number.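

On the core of compound 3, methoxy in place of methyl gave a 1.5-fold lower number from compound 3 to compound 4 (0.18 log units; within the scatter) in this assay. Each step alone lies within the scatter, yet the two run in opposite directions and the gap between them lies beyond it, so in this series the change did not carry over as a constant shift from one core to the other: the same change on two cores in this assay, a 2.0-fold higher number (0.29 log units; within the scatter) from compound 1 to compound 2 and a 1.5-fold lower number (0.18 log units; within the scatter) from compound 3 to compound 4, 3.0-fold (0.47 log units) apart, beyond the scatter of two such steps

This rests on a single pair per core, and it shows neither what produces the gap nor how the change would behave on a further core.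

The compounds shown leave open whether an amine or a chlorine in the same place would follow either step. They also leave open whether the hydroxy group shared by compound 3 and compound 4 has any part in the gap.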